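The source may report more compounds than this note shows. Statements on the series, on what has been measured and on what is new or still open speak of the compounds shown alone.

Compound 2, `CCCC(=O)OC1CCC(CN2CCN(c3cc(=O)c4cc(C(F)(F)F)cc([N+](=O)[O-])c4s3)CC2)CC1`, carries the (propylcarbonyl)oxy ester on the shared core. In an ADME assay on Vero cells (Chlorocebus sabaeus) for cytotoxicity, read by MTT assay, with a stated time of 48 h (a lower number here means a stronger inhibitor, a higher number a weaker inhibitor), compound 2 gives only a limit, > 64 ug/mL, and no number. Two near relatives are known. Compound 1, `O=C(OC1CCC(CN2CCN(c3cc(=O)c4cc(C(F)(F)F)cc([N+](=O)[O-])c4s3)CC2)CC1)c1ccccc1`, with phenyl on the carbonyl carbon, in this assay also stops at a limit, > 64 ug/mL. Compound 3, `C=CC(=O)OC1CCC(CN2CCN(c3cc(=O)c4cc(C(F)(F)F)cc([N+](=O)[O-])c4s3)CC2)CC1`, with vinyl there, in this assay likewise reports only the limit > 64 ug/mL. Hence the steps a step that the two limits leave unreadable from compound 1 to compound 2, a step that the two limits leave unreadable from compound 1 to compound 3 and a step that the two limits leave unreadable from compound 2 to compound 3 cannot be sized: all three values rest at the limit of > 64 ug/mL in this assay, at which 3 of the 3 values shown sit.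

Compound 4, `COc1ccccc1C(=O)OC1CCC(CN2CCN(c3cc(=O)c4cc(C(F)(F)F)cc([N+](=O)[O-])c4s3)CC2)CC1`, differs from compound 2 by 2-methoxyphenyl in place of propyl on a carbonyl carbon. Every measured exchange of the group on the carbonyl carbon, whether phenyl, propyl or vinyl, has left the reading at the limit, so the move to 2-methoxyphenyl gives no footing for expecting a shift. Compound 4 is therefore expected to show a step of about a number no higher from compound 2 to compound 4 (the limit leaves the size open), that is, none beyond the scatter. The estimate for compound 4 in this assay is 64 ug/mL, within 40 ug/mL to 100 ug/mL, with a strong likelihood that only a limit is again reported.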

Compound 4, half-maximal inhibitory concentration: > 64 ug/mL
Compound 4 was reported as a limit (the forecaster's own chance of this, stated with the estimate: 80%); the middle value sits exactly at the limit.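

In this assay compound 4 gives only a limit, > 64 ug/mL. Its steps from compound 1, compound 2 and compound 3 therefore cannot be read: the limit of > 64 ug/mL in this assay, at which 4 of the 4 values shown sit. The compounds shown leave open where any of the four truly lies and whether the group on the carbonyl carbon changes the reading at all.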